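The source may report more compounds than this note shows. Statements on the series, on what has been measured and on what is new or still open speak of the compounds shown alone.

Two compounds of this series have been run in an ADME assay on McCoy cells (Mus musculus) for antiproliferative activity, read by sulforhodamine B assay, with a stated time of 48 h; a higher number here means a weaker inhibitor, a lower number a stronger inhibitor. Compound 1 `C[C@@H]1N=C2C[C@@H]3C[C@@H](C3(C)C)[C@]2(C)OC1=O` gives only a limit there, > 2000000 nM. Compound 2 `CC(C)(C)OC(=O)CC[C@H]1N=C2C[C@H]3C[C@H](C3(C)C)[C@@]2(C)OC1=O` likewise gives only a limit, > 1200000 nM. Compound 1 sits at the limit of > 2000000 nM in this assay, at which 1 of the 2 values shown sits. Compound 2 sits at the limit of > 1200000 nM in this assay, at which 1 of the 2 values shown sits. Among the measured compounds shown here, neither value is a number, so compound 2 stands at a limit with no measured step to any other compound.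

Compound 3 `CC(C)(C)OC(=O)CC[C@@H]1N=C2C[C@@H]3C[C@@H](C3(C)C)[C@]2(C)OC1=O` is the mirror image of compound 2: the two compounds have the same atoms and bonds and differ only in configuration as drawn: 4 of 4 stereo elements differ (all stereocentres are inverted: mirror images); a stereocentre at a saturated ring carbon is drawn R in compound 2 and S in compound 3; a stereocentre at a saturated ring carbon is drawn R in compound 2 and S in compound 3; a stereocentre at a saturated ring carbon is drawn R in compound 2 and S in compound 3; a stereocentre at a saturated ring carbon is drawn R in compound 2 and S in compound 3. For the measured compounds named here, no measured step in this assay covers a change of this kind, and both measured compounds stand at limits; no shift beyond the scatter is expected in either direction, and the most likely outcome for compound 3 is again a limit rather than a number.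

Compound 3 is estimated at 1500000 nM in this assay, between 300000 nM and 5000000 nM, an expected step that the limit leaves unreadable from compound 2 to compound 3.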

Compound 3, half-maximal inhibitory concentration: > 1000000 nM
Compound 3 ended at the assay's limit; the forecaster's own chance of this, stated with the estimate: 85%; the middle value is on the limit's open side.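

In this assay, among the compounds shown here, compound 3 gives only a limit, > 1000000 nM, and no step from compound 1 or compound 2 to compound 3 can be read. The compounds shown leave open whether inverting all stereocentres changes this read-out, and where any of the three compounds would give a number.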